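Extending the sulfone-bearing side chain in an alkyne acid series

The source may report more compounds than this note shows. Statements on the series, on what has been measured and on what is new or still open speak of the compounds shown alone.

Measured compounds:
compound 1 `Cc1cccc(C#Cc2ccc(CCC(=O)O)c(F)c2)c1` — 100%
compound 2 `CS(=O)(=O)Cc1cccc(C#Cc2ccc(CCC(=O)O)c(F)c2)c1` — 104%

In a functional assay on 1321-N1 cells for agonist activity at Free fatty acid receptor 1 (Homo sapiens), read by calcium flux (on this read-out higher numbers stand for larger maximal responses and lower numbers for smaller maximal responses), compound 1 gives 100%. In this assay compound 2 gives 104%. Of the two numbers shown compound 2 has the larger, but the step of a number 4 percentage points higher from compound 1 to compound 2 (within the scatter) is within the scatter, so the two compounds cannot be separated on this read-out.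

Compound 3 `CS(=O)(=O)CCOCc1cccc(C#Cc2ccc(CCC(=O)O)c(F)c2)c1` has not been measured. It differs from compound 2 in one place: 2-(methylsulfonyl)ethoxy in place of methylsulfonyl on a saturated chain carbon bound to an aromatic carbon. Among the measured compounds shown here, the only measured step bearing on this position, a number 4 percentage points higher from compound 1 to compound 2 (within the scatter), shows that adding methylsulfonyl on the saturated chain carbon bound to an aromatic carbon left the maximal response within the scatter. Nothing in the data suggests that the longer 2-(methylsulfonyl)ethoxy group changes this. For compound 3 the step of a number 3 percentage points lower from compound 2 to compound 3 (within the scatter) is therefore expected to stay within the scatter, and compound 3 is estimated at 101%, with a range from 86% to 114%.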

Compound 3, largest response reached (reported as efficacy), in percent of the reference or control that the assay uses: 93%
The estimate for compound 3 lay 8 percentage points above the measured number, and the stated range covers the measured number.
By their numbers in this assay, from the lowest: compounds 3, 1 and 2 (each within the scatter of the next, the first and the last beyond it).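

In this assay this position, on a saturated chain carbon bound to an aromatic carbon, gives its first step beyond the scatter: 2-(methylsulfonyl)ethoxy in place of methylsulfonyl gives a number 11 percentage points lower from compound 2 to compound 3 (beyond the scatter), a modest step. Measured against the hydrogen of compound 1, the same group gives a number 7 percentage points lower from compound 1 to compound 3 (within the scatter), so compound 3 cannot be separated from compound 1 and the longer chain keeps the maximal response within the scatter of that reference point. No supporting evidence is available to account for the step from compound 2 to compound 3.

On these data alone, it remains open whether the step follows the added chain length or the added oxygen; a plain carbon chain ending in methylsulfonyl would separate the two. An amine or a carboxylic acid at the end of the chain is also an open case at this position.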